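Removing One Cyano Group Across Two Matched Pairs

The compounds below may be only part of what the source reports. "The series", "measured", "known", "first", "only" and "open" are said of these compounds alone.

Measured compounds:
compound 1, `N#Cc1ccc(Sc2ccc(Br)cc2)cc1C#N`, 79 nM
compound 2, `N#Cc1ccc(SCCc2ccccc2)cc1C#N`, 124 nM
compound 3, `N#Cc1ccc(Sc2ccc(Br)cc2)cc1`, 637 nM

All three compounds were tested in an assay on microsomes for inhibition of Amine oxidase [flavin-containing] B (Homo sapiens), read by fluorescence and spectrophotometry, with a stated time of 20 min; a higher number here means a weaker inhibitor, a lower number a stronger inhibitor. Compound 1 gives 79 nM, compound 2 gives 124 nM and compound 3 gives 637 nM. The numbers for compound 1 and compound 2 lie within the scatter of each other, while compound 3 stands beyond the scatter from both.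

Compound 3 arises from compound 1 by a single change, (hydrogen in place of cyano on an aromatic carbon). Its step in this assay is an 8.1-fold higher number from compound 1 to compound 3 (0.91 log units; beyond the scatter).

Compound 4, `N#Cc1ccc(SCCc2ccccc2)cc1`, has not yet been measured. It arises from compound 2 by hydrogen in place of cyano on an aromatic carbon. Among the compounds with values here, this is the same kind of change as the one from compound 1 to compound 3, though the surroundings are not identical: in compound 1 the place is meta to a group of 8 heavy atoms, whereas in compound 2 it is meta to a group of 9 heavy atoms. The difference between the two cores of compound 1 and compound 2 is not broken down here.

In this assay, within the data shown here, compound 4 is expected to show a step of an 8.1-fold higher number from compound 2 to compound 4 (0.91 log units; beyond the scatter), set beside the measured 8.1-fold higher number from compound 1 to compound 3 (0.91 log units; beyond the scatter), because the only precedent for this change is an 8.1-fold higher number from compound 1 to compound 3 (0.91 log units; beyond the scatter). Starting from compound 2 at 124 nM, compound 4 is estimated at 1000 nM, with a likely range from 350 nM to 3000 nM.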

Compound 4, half-maximal inhibitory concentration: 1810 nM
For compound 4 the middle estimate is 1.8-fold (0.26 log units) below the measured one; the range from low to high includes it.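

In this assay, hydrogen in place of cyano on an aromatic carbon acts on the core of compound 2 in the same direction as on the core of compound 1, with a 15-fold higher number from compound 2 to compound 4 (1.16 log units; beyond the scatter) as the new result, so inhibition is again clearly weaker once this cyano group has gone. The two steps also agree in size, as far as a pair of steps can show this: the same change on two cores in this assay, an 8.1-fold higher number (0.91 log units; beyond the scatter) from compound 1 to compound 3 and a 15-fold higher number (1.16 log units; beyond the scatter) from compound 2 to compound 4, 1.8-fold (0.26 log units) apart, within the scatter of two such steps. Within the data shown here, this supports carrying the change between these two cores, but it rests on only two matched pairs, so it does not establish a rule for the series or for any other core, and it does not explain what the cyano group contributes to inhibition.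

Hydrogen is the only replacement for this cyano group shown here, so it remains open what a chlorine atom, a methoxy group or a carboxylic acid in the same place would do, and what would follow from removing the remaining cyano group as well. Going by these compounds, it is also open whether a step of similar size would appear on a core carrying a longer chain or an amine.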